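A few compounds are considered here, and "the series" means these few. Any claim that something is new, unique, unknown or untested is made for them only; others in the source may bear on it.

Measured in a functional assay on HepG2 cells (Homo sapiens) for antiproliferative activity, read by MTT assay, with a stated time of 48 h; on this read-out lower numbers stand for stronger inhibition of growth and higher numbers for weaker inhibition of growth
compound 1 `COC(=O)N1N=C(c2cccc(OC)c2)CC1c1cc(OC)c(OC)c(OC)c1` gives 1870 nM
compound 2 `CCOc1cccc(C2=NN(C(=O)OC)C(c3cc(OC)c(OC)c(OC)c3)C2)c1` gives 8360 nM
compound 3 `COC(=O)N1N=C(c2cccc(Cl)c2)CC1c1cc(OC)c(OC)c(OC)c1` gives 1240 nM

Compound 3 (1240 nM) cannot be separated from compound 1, whereas compound 2 stands clearly apart from it.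

The unmeasured compound 4 `COC(=O)N1N=C(c2ccc(O)cc2)CC1c1cc(OC)c(OC)c(OC)c1` carries 4-hydroxyphenyl in place of 3-chlorophenyl on a carbon with a double bond to nitrogen.

The nearest evidence comes from substituent swaps on the corresponding aromatic ring. Chloro in place of methoxy gave a 1.5-fold lower number from compound 1 to compound 3 (0.18 log units; within the scatter), while chloro in place of ethoxy gave a 6.7-fold lower number from compound 2 to compound 3 (0.83 log units; beyond the scatter). The remaining step, a 4.5-fold higher number from compound 1 to compound 2 (0.65 log units; beyond the scatter), also ran to a higher number. Within the data shown here, no measured compound carries 4-hydroxyphenyl, so these steps offer only a rough guide to size and a weak guide to direction.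

In this assay a modest move to a higher number is therefore expected, smaller than the largest step seen so far, and a result within the scatter would not be surprising. The expected step is a 2.3-fold higher number from compound 3 to compound 4 (0.35 log units; beyond the scatter). For compound 4 the estimated value is 2800 nM, with an expected range of 900 nM to 9000 nM.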

Compound 4, concentration for 50% growth inhibition: 7820 nM
Compound 4: the middle estimate sits 2.8-fold (0.45 log units) below what was measured; the range from low to high includes it.
By their numbers in this assay, from the lowest: compounds 3 and 1 (each within the scatter of the next); then compounds 4 and 2 (each within the scatter of the next).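

In this assay, the aromatic group on the carbon with a double bond to nitrogen does not tolerate every change: 4-hydroxyphenyl gives a 6.3-fold higher number from compound 3 to compound 4 (0.80 log units; beyond the scatter) when it replaces 3-chlorophenyl and a 4.2-fold higher number from compound 1 to compound 4 (0.62 log units; beyond the scatter) when it replaces 3-methoxyphenyl, so the pair that could not be separated earlier now shares a clear step to one new group. Replacing 3-ethoxyphenyl with the same group gives a 1.1-fold lower number from compound 2 to compound 4 (0.03 log units; within the scatter) on the same read-out, so the higher numbers are no longer tied to the ethoxy compound alone, and two different aromatic groups now stand level, apart from compound 1 and compound 3. Nothing shown here speaks to the cause of these steps.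

The compounds shown leave open whether the step follows the hydroxy group or its place on the ring, as 4-hydroxyphenyl differs from 3-chlorophenyl in both, and 3-hydroxyphenyl and 4-chlorophenyl would separate the two. Also open, on these data alone, is how an amine or a carboxylic acid on this ring would read, and whether a longer chain in place of the methoxycarbonyl group would shift the numbers.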